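The compounds below may be only part of what the source reports. "The series", "measured", "known", "first", "only" and "open" are said of these compounds alone.

In a functional assay on SW480 cells (Homo sapiens) for antiproliferative activity, read by MTT assay, with a stated time of 48 h (on this read-out lower numbers stand for stronger inhibition and higher numbers for weaker inhibition), compound 1 `COC/C1=C/C[C@](C)(CCC=C(C)C)/C=C/[C@@H](OC(=O)C=C(C)C)[C@](C)(OC)/C=C/C1=O` gives 14600 nM and compound 2 `CC(=O)O[C@]1(C)/C=C/C(=O)/C(CO)=C\C[C@](C)(CCC=C(C)C)/C=C/[C@H]1OC(=O)C=C(C)C` gives 2010 nM, the lower of the two numbers, by a gap beyond the usual scatter. Compound 3 `CO[C@]1(C)/C=C/C(=O)/C(CO)=C\C[C@](C)(CCC=C(C)C)/C=C/[C@H]1OC(=O)C=C(C)C` differs from compound 2 by methyl in place of acetyl on an oxygen on a saturated carbon, with methyl in place of acetyl on an oxygen on a saturated carbon. Among the compounds with values here, no measured step shows this change alone. Within the data shown here, with compound 1 at 14600 nM as the only other measured number, a rise rather than a fall is expected. The expected step is moderate, a 2.5-fold higher number from compound 2 to compound 3 (0.40 log units; beyond the scatter), and only modestly beyond the scatter. Compound 3 is estimated at 5000 nM, with an expected range of 1800 nM to 14000 nM.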

Compound 3, half-maximal inhibitory concentration: 15200 nM
For compound 3 the middle estimate is 3.0-fold (0.48 log units) below the measured one, outside the stated range (above it).
By their numbers in this assay, from the lowest: compound 2; then compounds 1 and 3 (each within the scatter of the next).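

In this assay, acetoxy to methoxy on the saturated carbon gives a 7.6-fold higher number from compound 2 to compound 3 (0.88 log units; beyond the scatter), so at this position the acetyl carries the lower number of compound 2, and a methyl does not retain it. The other listed change, hydrogen in place of methyl on an oxygen on a saturated carbon, gives a 1.0-fold higher number from compound 1 to compound 3 (0.02 log units; within the scatter), so that swap leaves the number unchanged within the scatter. Nothing available explains why the acetyl matters here. On these data alone, it remains open whether the ester link itself is what counts. A butanoyl or benzoyl group on this oxygen could show whether other esters match acetyl.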